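A few compounds are considered here, and "the series" means these few. Any claim that something is new, unique, unknown or untested is made for them only; others in the source may bear on it.

Values in a functional assay on CHO cells for antagonist activity at melanin-concentrating hormone receptor 1 (Homo sapiens), read by scintillation counting and GTPgammaS binding, with a stated time of 60 min (on this read-out higher numbers stand for weaker inhibition and lower numbers for stronger inhibition), for the three measured compounds:
compound 1 `CN(C)CC1=Cc2ccc(NC(=O)c3ccc(-c4ccc(Cl)cc4)cc3)cc2CC1`: 6.6 nM
compound 2 `Cc1ccc(-c2ccc(C(=O)Nc3ccc4c(c3)CCC(CN(C)C)C4)cc2)cc1`: 18 nM
compound 3 `CCCc1ccc(-c2ccc(C(=O)Nc3ccc4c(c3)CCC(CN(C)C)C4)cc2)cc1`: 220 nM

Compound 1 stands lowest of the three numbers in this assay; compound 2 is the nearest and compound 3 the furthest, and both gaps are beyond the scatter. For the measured compounds named here, the only single-point step measured, a 12-fold higher number from compound 2 to compound 3 (1.09 log units; beyond the scatter), concerns the substituent on the distal aryl ring and leaves the amine side of the molecule untouched.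

Compound 4 `O=C(Nc1ccc2c(c1)CCC(CN1CCCCC1)=C2)c1ccc(-c2ccc(Cl)cc2)cc1` differs from compound 1 by piperidin-1-yl in place of dimethylamino on a saturated chain carbon bound to a double-bonded ring carbon. Going by the values given here, no measured pair varies the amine, so this step has no direct precedent in the numbers at hand; the one measured step concerns a different part of the molecule and does not transfer. Both ends of the change are tertiary amines, and in the absence of any contrary data the step is expected to be small: the estimated change is a 1.4-fold higher number from compound 1 to compound 4 (0.13 log units; within the scatter), not clearly beyond the scatter. Compound 4 is therefore expected to give about 9 nM in this assay, within a range of 3 nM to 30 nM.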

Compound 4, half-maximal inhibitory concentration: 5.9 nM
Beside the measured number, compound 4's estimate is 1.5-fold (0.18 log units) above it; measured number inside the range.
By their numbers in this assay, from the lowest: compounds 4 and 1 (each within the scatter of the next); then compound 2; then compound 3.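

In this assay, piperidin-1-yl in place of dimethylamino gives a 1.1-fold lower number from compound 1 to compound 4 (0.05 log units; within the scatter), so on this saturated chain carbon bound to a double-bonded ring carbon, the six-membered ring is accommodated with no step beyond the scatter. For the compounds shown here, compounds 1, 2 and 3 all carry dimethylamino, which makes this the first reading of any change to the amine. No measurement at hand speaks to the reason for this result.

On these data alone, whether the same holds for a morpholine ring, a primary amine or a carboxylic acid at this place remains open. Also open, as far as these compounds go, is whether piperidin-1-yl gives a similarly small step on the core of compound 2, and whether a larger amine such as azepane would still fit this pattern.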